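The source may report more compounds than this note shows. Statements on the series, on what has been measured and on what is new or still open speak of the compounds shown alone.

Working notes on the series. Among the compounds with values here, compound 1 `Cc1ccc(C(=O)Oc2ccc(Cl)cc2C(=O)Nc2ccc(C(F)(F)F)cc2)cc1` and compound 2 `O=C(Oc1ccc(Br)cc1C(=O)Nc1ccc(C(F)(F)F)cc1)c1ccc([N+](=O)[O-])cc1` are the two compounds measured so far in an ADME assay on HepG2 cells (Homo sapiens) for cytotoxicity, read by MTT assay, with a stated time of 72 h; a higher number here means a weaker inhibitor, a lower number a stronger inhibitor. In this assay compound 1 gives > 50000 nM, a limit of the assay and not a number. In this assay compound 2 also gives > 50000 nM, again a limit rather than a measured figure. Where compound 2 stands is therefore known only as a limit: both values shown sit at the limit of > 50000 nM in this assay, at which 2 of the 2 values shown sit, so no ordering between compound 1 and compound 2 can be read from these numbers.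

Compound 3 `Cc1ccc(C(=O)Oc2ccc(Br)cc2C(=O)Nc2ccc(C(F)(F)F)cc2)cc1` has not yet been measured in this assay. It differs from compound 2 in one place: methyl in place of nitro on an aromatic carbon. Within the data shown here, no measured step of this kind exists, so the size of the change cannot be taken from data; the only anchor is that compound 1, which carries the same methyl, sits at the same limit as compound 2. A step from compound 2 to compound 3 of a step that the limit leaves unreadable from compound 2 to compound 3 is expected, that is none beyond the scatter. Compound 3 is therefore estimated at 80000 nM, within 30000 nM to 200000 nM, most likely reported as a limit.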

Compound 3, half-maximal inhibitory concentration: > 50000 nM
Compound 3 gave a limit, no number; the forecaster's own chance of this, stated with the estimate: 85%; the middle value does not contradict the limit.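

In this assay compound 3 gives > 50000 nM, a limit and not a number. Within the data shown here, no step among compound 1, compound 2 and compound 3 can be read from this: the limit of > 50000 nM in this assay, at which 3 of the 3 values shown sit. The compounds shown leave open whether methyl in place of nitro, or bromo in place of chloro, changes anything in this assay.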